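Swapping an acetamidomethyl for a methoxycarbonyl on a benzimidazole scaffold

The source may report more compounds than this note shows. Statements on the series, on what has been measured and on what is new or still open speak of the compounds shown alone.

Two measured compounds set the stage. Compound 1 `CC(=O)NCc1ccc2c(c1)nc(Cn1c(=O)n(C(C)C)c3ccccc31)n2CCC(C)C` was tested in an ADME assay on HEp-2 cells (Homo sapiens) for cytotoxicity (on this read-out higher numbers stand for lower toxicity in this test and lower numbers for higher toxicity in this test), and in this assay compound 1 gives 178000 nM, the higher of the two numbers seen so far, which means the lower toxicity of the pair. Compound 2 `C=C(C)n1c(=O)n(Cc2nc3cc(C(C)=O)ccc3n2CCC(C)C)c2ccccc21` in this assay gives 740 nM, a far lower number, and the gap between these two values is well beyond the usual scatter.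

Compound 3 `COC(=O)c1ccc2c(c1)nc(Cn1c(=O)n(C(C)C)c3ccccc31)n2CCC(C)C` has not yet been measured. It differs from compound 1 in one place: methoxycarbonyl in place of acetamidomethyl on an aromatic carbon. For the measured compounds named here, no measured pair shares exactly this change, so no step can be borrowed from the data. Going by the values given here, the only guide is that compound 1 with its acetamidomethyl sits at 178000 nM while compound 2, which carries different groups, sits at 740 nM.

Compound 3 is expected to land between the two measured values, with a step of an 8.9-fold lower number from compound 1 to compound 3 (0.95 log units; beyond the scatter) toward a lower number from compound 1, an estimate of 20000 nM within a range from 2000 nM to 150000 nM.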

Compound 3, half-maximal cytotoxic concentration: 33700 nM
Beside the measured number, compound 3's estimate is 1.7-fold (0.23 log units) below it; the measured number falls inside the stated range.
By their numbers in this assay, from the lowest: compound 2; then compound 3; then compound 1.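

In this assay, changing a single group on the shared core, methoxycarbonyl in place of acetamidomethyl on this aromatic carbon, gives a 5.3-fold lower number from compound 1 to compound 3 (0.72 log units; beyond the scatter). The earlier pair could not show this, since compound 1 and compound 2 differ in more than one place, whereas here the change in number belongs to this one position, and the position clearly responds to what it carries. The counts do differ, with the leaving acetamidomethyl carrying 1 hydrogen-bond donor and the entering methoxycarbonyl 0 hydrogen-bond donors and 2 hydrogen-bond acceptors, but no measurement here ties the step to that difference or to any other feature of the two groups.

Going by these compounds, one swap at one position cannot show a trend, so it remains open how a carboxylic acid or an aminomethyl group on this same aromatic carbon would read in this assay. On these data alone, it is also open whether methoxycarbonyl in place of acetamidomethyl gives a step of similar size when the rest of the molecule carries the other groups of compound 2.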